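This account rests on a few compounds, and the source may have more. Where it says the series, first, only, none or still open, it means among the compounds named here.

Four close relatives are compared in a functional assay on Caco-2 cells (Homo sapiens) for inhibition, read by sulforhodamine B assay, with a stated time of 72 h; a lower number here means a stronger inhibitor, a higher number a weaker inhibitor. Compound 1 `CCC(C)NC(=C\C(=O)/C=C/c1ccc(O)c(OC)c1)/C=C/c1ccc(O)c(OC)c1` gives only a limit there, > 25000 nM. Compound 2 `COc1cc(/C=C/C(=O)/C=C(/C=C/c2ccc(O)c(OC)c2)NC2CCCCC2)ccc1O` gives 5100 nM in this assay, and the change between the two, (cyclohexyl in place of sec-butyl on an amine nitrogen), made an at least 4.9-fold lower number from compound 1 to compound 2 (0.69 log units; beyond the scatter); the size of that step rests on the limit of > 25000 nM in this assay, at which 1 of the 3 values shown sits, rather than on a measured number. Compound 3 `CCC(C)NC(=C\C(=O)/C=C/c1ccc(O)cc1)/C=C/c1ccc(O)cc1` gives 5800 nM in this assay; its value and that of compound 2 lie within the usual scatter of each other. How the core of compound 3 differs from that of compound 1 is not broken down here. Compound 4 `O=C(/C=C(/C=C/c1ccc(O)cc1)NC1CCCCC1)/C=C/c1ccc(O)cc1` has not yet been measured; it carries the same change, (cyclohexyl in place of sec-butyl on an amine nitrogen), at the same place. Taking the earlier step as the guide, compound 4 is expected to show a 2.3-fold lower number from compound 3 to compound 4 (0.37 log units; beyond the scatter). Compound 4 is therefore estimated at 2500 nM, most likely between 800 nM and 8000 nM.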

Compound 4, half-maximal inhibitory concentration: 6900 nM
Compound 4: middle estimate off by 2.8-fold (0.44 log units), on the low side; low and high end bracket the measured number.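

In this assay, cyclohexyl in place of sec-butyl on the amine nitrogen gave a 1.2-fold higher number from compound 3 to compound 4 (0.08 log units; within the scatter). The change therefore did not carry over in the same way from the core of compound 1 to the core of compound 3: the same change on two cores in this assay, an at least 4.9-fold lower number (0.69 log units; beyond the scatter) from compound 1 to compound 2 and a 1.2-fold higher number (0.08 log units; within the scatter) from compound 3 to compound 4, at least 5.8-fold (0.76 log units) apart, beyond the scatter of two such steps. This gap gives no reason for the difference, and its exact size stays unknown, as the earlier step rests on a limit: the limit of > 25000 nM in this assay, at which 1 of the 4 values shown sits.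

Going by these compounds alone, only two cores are compared here, so no rule for other cores follows. Still open, as far as these compounds go, is whether other groups on that nitrogen, such as a straight butyl chain or a benzyl group, would behave differently on these two cores.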